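Methyl for Nitro on a Low-Toxicity Amide

This account rests on a few compounds, and the source may have more. Where it says the series, first, only, none or still open, it means among the compounds named here.

Compound 1 `Cc1cc(C)c(Oc2cc(Nc3ccc(C#N)cc3)ncc2C(=O)NCc2cn(CCCO)nn2)c(C)c1` gives 25200 nM in an ADME assay on MT4 cells (Homo sapiens) for cytotoxicity, read by MTT assay, with a stated time of 5 days; on this read-out higher numbers stand for lower toxicity in this test and lower numbers for higher toxicity in this test. Compound 2 `Cc1cc(C)c(Oc2cc(Nc3ccc(C#N)cc3)ncc2C(=O)NCc2cn(Cc3ccc([N+](=O)[O-])cc3)nn2)c(C)c1` reaches only a limit of >= 139000 nM in this assay, namely (the limit of >= 139000 nM in this assay, at which 1 of the 2 values shown sits). The change between the two gave an at least 5.5-fold higher number from compound 1 to compound 2 (0.74 log units; beyond the scatter). Compound 3 `Cc1ccc(Cn2cc(CNC(=O)c3cnc(Nc4ccc(C#N)cc4)cc3Oc3c(C)cc(C)cc3C)nn2)cc1` differs from compound 2 by methyl in place of nitro on an aromatic carbon. Going by the values given here, no measured step exchanges one group for another on that ring, so the sole guide is that compound 2 sits at the limit. Compound 3 is therefore expected to stay close to that limit, with an estimated a number no higher from compound 2 to compound 3 (the limit leaves the size open) and an expected 139000 nM in this assay, between 50000 nM and 300000 nM.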

Compound 3, half-maximal cytotoxic concentration: 165000 nM
Beside the measured number, compound 3's estimate is 1.2-fold (0.07 log units) below it; the measured number falls inside the stated range.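

With methyl in place of nitro, the aromatic group still brings a clear rise in this assay, with a 6.5-fold higher number from compound 1 to compound 3 (0.82 log units; beyond the scatter). The nitro group is therefore not required for the low toxicity seen in this test. The step between nitro and methyl itself cannot be read because compound 2 gives only a limit: the limit of >= 139000 nM in this assay, at which 1 of the 3 values shown sits.

The compounds shown leave open whether an amine or a carboxylic acid in place of that methyl would keep the number this high. They also leave open whether a longer chain without an aromatic ring would do the same.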